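A few compounds are considered here, and "the series" means these few. Any claim that something is new, unique, unknown or untested is made for them only; others in the source may bear on it.

Measured so far:
compound 1 `CCc1nc(N)[nH]c(=O)c1-c1ccc(Cl)cc1`, in an assay for inhibition of beta-N-acetyl-D-hexosaminidase-A/B (Homo sapiens) (a higher number here means a weaker inhibitor, a lower number a stronger inhibitor), a limit only, > 2100000 nM.
compound 2 `CCc1nc(N)nc(N)c1-c1ccccc1C`, in this assay 43000 nM.
compound 3 `CCc1nc(N)ncc1-c1ccc(Cl)cc1`, in this assay a limit only, > 400000 nM.

Compound 3 stands among the limit readings, not among the numbers: its result in this assay is the limit of > 400000 nM in this assay, at which 1 of the 3 values shown sits. Compound 1 sits likewise at a limit, (the limit of > 2100000 nM in this assay, at which 1 of the 3 values shown sits). Only compound 2 gives an actual number.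

Compound 4 `CCc1nc(N)ncc1-c1ccc(C(F)(F)F)cc1` differs from compound 3 by trifluoromethyl in place of chloro on an aromatic carbon. Among the compounds with values here, no measured step of this kind exists among the three compounds, so in this assay no movement beyond the scatter is expected in either direction. Compound 4 is expected at 500000 nM, in the range 100000 nM to 3000000 nM, most probably again reported as a limit. The expected step is a step that the limit leaves unreadable from compound 3 to compound 4.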

Compound 4, half-maximal inhibitory concentration: > 400000 nM
Compound 4 ended at the assay's limit; the forecaster's own chance of this, stated with the estimate: 75%; the middle value is on the limit's open side.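

In this assay compound 3 gives the limit > 400000 nM. Within the data shown here, compound 4 gives the limit > 400000 nM, so no step between compound 3 and compound 4 can be read. Going by these compounds, whether trifluoromethyl in place of chloro changes inhibition stays open.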